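Swapping a halogen on the outer aryl ring

This account rests on a few compounds, and the source may have more. Where it says the series, first, only, none or still open, it means among the compounds named here.

Compound 1 `O=[N+]([O-])c1ccc(CN2CCC(n3cc(CC(OCc4cc(-c5ccc(Br)cc5)no4)c4ccc(Br)cc4)nn3)CC2)cc1` gives 2000 nM in a functional assay on Huh-7 cells (Homo sapiens) for cytotoxicity, with a stated time of 48 h; a lower number here means a stronger inhibitor, a higher number a weaker inhibitor.
Compound 2 `COc1ccc(-c2cc(COC(Cc3cn(C4CCN(Cc5ccc([N+](=O)[O-])cc5)CC4)nn3)c3ccc(Br)cc3)on2)cc1` gives 2000 nM in this assay.
Compound 3 `O=[N+]([O-])c1ccc(CN2CCC(n3cc(CC(OCc4cc(-c5cccc(Br)c5)no4)c4ccc(Br)cc4)nn3)CC2)cc1` gives 3000 nM in this assay.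

Compound 3 stands at a 1.5-fold higher number from compound 1 to compound 3 (0.18 log units; within the scatter) and a 1.5-fold higher number from compound 2 to compound 3 (0.18 log units; within the scatter). Compound 4 `O=[N+]([O-])c1ccc(CN2CCC(n3cc(CC(OCc4cc(-c5cccc(F)c5)no4)c4ccc(Br)cc4)nn3)CC2)cc1` differs from compound 3 by fluoro in place of bromo on an aromatic carbon. Within the data shown here, the steps that bear on this outer aryl ring are no change at the digits printed from compound 1 to compound 2 (within the scatter), a 1.5-fold higher number from compound 1 to compound 3 (0.18 log units; within the scatter) and a 1.5-fold higher number from compound 2 to compound 3 (0.18 log units; within the scatter), all within the scatter, so changes on this ring have so far left this assay essentially unmoved. The expected step from compound 3 to compound 4 is therefore no change at the digits printed from compound 3 to compound 4 (within the scatter), no change beyond the scatter. For compound 4 the estimate in this assay is 3000 nM, expected to fall between 1500 nM and 6000 nM.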

Compound 4, half-maximal inhibitory concentration: 3000 nM
Compound 4: the middle estimate sits on the measured number at the digits printed, and the stated range covers the measured number.
By their numbers in this assay, from the lowest: compounds 1, 2, 3 and 4 (each within the scatter of the next).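

Among these compounds, the first exchange of one halogen for another on this ring gives no change at the digits printed from compound 3 to compound 4 (within the scatter) in this assay and so adds the choice of halogen to the changes that leave this read-out flat. The other two steps read a 1.5-fold higher number from compound 2 to compound 4 (0.18 log units; within the scatter) and a 1.5-fold higher number from compound 1 to compound 4 (0.18 log units; within the scatter) so 3-fluorophenyl sits level with the 4-methoxyphenyl and 4-bromophenyl groups. Nothing measured here explains this flatness.

Going by these compounds, whether an amine or a carboxylic acid on this ring would move the number stays open. So does whether changes elsewhere on the shared core would matter.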